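Ring swap on the aromatic nitrogen: compound 3 to compound 4

This account rests on a few compounds, and the source may have more. Where it says the series, first, only, none or still open, it means among the compounds named here.

compound 1, `CN1CCN(c2ccc(Nc3ncc4nc(Nc5ccc(F)cc5)n([C@@H]5CCCNC5)c4n3)cc2)CC1`: "not determined" (no result reported)
compound 2, `CCOC(=O)CN1CC[C@H](n2c(Nc3ccc(F)cc3)nc3cnc(Nc4ccc(N5CCN(C)CC5)cc4)nc32)C1`: "not determined" (no result reported)
compound 3, `CN1CCN(c2ccc(Nc3ncc4nc(Nc5ccc(F)cc5)n([C@@H]5CCN(S(=O)(=O)C6CC6)C5)c4n3)cc2)CC1`: > 10000 nM

All three measured entries share one core and differ only in the group on the aromatic nitrogen. Compounds 1 and 2 carry no result in a functional assay on A549 cells (Homo sapiens) for antiproliferative activity, read by MTT assay, with a stated time of 72 h; a lower number here means a stronger inhibitor, a higher number a weaker inhibitor. For the measured compounds named here, compound 3 is the sole entry with a reading, and that reading is a limit of the assay rather than a number: in this assay compound 3 gives > 10000 nM. This reading sits at the limit of > 10000 nM in this assay, at which 1 of the 3 values shown sits, so nothing finer than the limit is known for it.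

Compound 4, `CN1CCN(c2ccc(Nc3ncc4nc(Nc5ccc(F)cc5)n([C@H]5CCCN(C(=O)CO)C5)c4n3)cc2)CC1`, differs from compound 3 in one place: 1-((hydroxymethyl)carbonyl)piperidin-3-yl in place of 1-(cyclopropylsulfonyl)pyrrolidin-3-yl on an aromatic nitrogen. Going by the values given here, no step between two measured compounds exists in this set, so the size of such a change has no anchor, and any expectation rests on the limit of compound 3 alone.

Given that compound 3 gives only > 10000 nM, compound 4 is expected to stay weak, and the step of an at least 1.1-fold lower number from compound 3 to compound 4 (0.04 log units; that floor lies within the scatter) is expected to lie within the scatter or at most modestly toward stronger inhibition. For compound 4 the estimate in this assay is 9000 nM, with a range from 1500 nM to 30000 nM.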

Compound 4, half-maximal inhibitory concentration: 830 nM
Beside the measured number, compound 4's estimate is 11-fold (1.04 log units) above it, outside the stated range (below it).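

In this assay the group on the aromatic nitrogen turns out to decide whether this series gives a reading short of the assay limit, with an at least 12-fold lower number from compound 3 to compound 4 (1.08 log units; beyond the scatter) when 1-((hydroxymethyl)carbonyl)piperidin-3-yl replaces 1-(cyclopropylsulfonyl)pyrrolidin-3-yl. The ring, the sulfonyl-to-carbonyl link and the cyclopropyl-to-hydroxymethyl end all change together, so the step belongs to the whole replacement and to no single part of it. The reading of compound 3 is a limit, so the step gives only a floor on the true size: the limit of > 10000 nM in this assay, at which 1 of the 4 values shown sits.

The compounds shown leave open which of these parts carries the step, a question that 1-(cyclopropylsulfonyl)piperidin-3-yl or 1-((hydroxymethyl)carbonyl)pyrrolidin-3-yl would separate. Also open, on these data alone, is what the hydroxymethyl end contributes, which a plain acetyl group or a methoxyacetyl group on the same piperidine would address.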